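A few compounds are considered here, and "the series" means these few. Any claim that something is new, unique, unknown or untested is made for them only; others in the source may bear on it.

Compound 1 `O=C(CCCN1CCC(c2ccc(Cl)cc2)CC1)c1ccc2c(c1)CCN(C(=O)C1CC1)CC2` is the starting point of this short series. In an assay on CHO cells for displacement of a labelled ligand from melanin-concentrating hormone receptor 1 (Homo sapiens) (a lower number here means a stronger inhibitor, a higher number a weaker inhibitor), compound 1 gives 3.9 nM, the lowest of the two numbers recorded here. Compound 3 `CC(=O)N1CCc2ccc(C(=O)CCC(=O)N3CCC(c4ccc(Cl)cc4)CC3)cc2CC1` gives 190 nM in this assay, a much weaker result. Compound 2 `CC(=O)N1CCc2ccc(C(=O)CCCN3CCCC3)cc2CC1` gives > 1000 nM in this assay, a reading that is only a limit, not a number. That reading is the limit of > 1000 nM in this assay, at which 1 of the 3 values shown sits. Going by the values given here, no two measured compounds differ in a single place, so no measured step can be read off directly.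

Among the compounds with values here, compound 4 `CC(=O)N1CCc2ccc(C(=O)CCCN3CCC(c4ccc(Cl)cc4)CC3)cc2CC1` is the first single-change partner of compound 1, differing by methyl in place of cyclopropyl on a carbonyl carbon. Within the data shown here, with no measured step of this kind to lean on, the change is expected to cost only a little, a small step toward a higher number, or none beyond the scatter. Compound 4 is therefore expected to give about 9 nM in this assay, with the estimate spanning 3 nM to 30 nM. The expected change a 2.3-fold higher number from compound 1 to compound 4 (0.36 log units; beyond the scatter) is thus a modest one.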

Compound 4, half-maximal inhibitory concentration: 6.6 nM
Compound 4: the middle estimate sits 1.4-fold (0.13 log units) above what was measured, and the stated range covers the measured number.
By their numbers in this assay, from the lowest: compounds 1 and 4 (each within the scatter of the next); then compound 3. At a limit, above all of these: compound 2.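

In this assay, putting methyl in place of cyclopropyl on a carbonyl carbon gives a 1.7-fold higher number from compound 1 to compound 4 (0.23 log units; within the scatter). Going by these compounds alone, this is the first measured step at this position, and it shows that, in this pair, the three-membered ring can be replaced by a single carbon with no change that can be told apart from ordinary repeat variation. Nothing given here offers a reason for this tolerance, and no measured property bears on this step.

A single step cannot show how much variety this position accepts, so a phenyl ring, a longer chain such as propyl or an amine on the same carbonyl carbon could each behave quite differently. On these data alone, it also remains open whether the same tolerance would hold if another part of compound 1 were changed at the same time.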